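Second fluoro on the 4-fluorophenyl ketone: expected cytotoxicity

The source may hold more compounds than are shown below. What is called first, only, known or untested is meant among the compounds shown, and "the series" means these compounds.

Compound 1 `CCOC(=O)c1sc2nc(-c3cccs3)ccc2c1N` and compound 2 `Nc1c(C(=O)c2ccc(F)cc2)sc2nc(-c3cccs3)ccc12` share one core. In a functional assay on WI-38 VA13 cells (Homo sapiens) for cytotoxicity (a lower number here means that less compound is needed, a higher number that more compound is needed for the effect), compound 1 reaches only the limit > 4 ug/mL. In this assay, going by the values given here, compound 2 gives 1.8 ug/mL, the only actual number in the set, so compound 2 has no measured neighbour with a number to stand against. Among the compounds with values here, the one measured step, an at least 2.2-fold lower number from compound 1 to compound 2 (0.34 log units; beyond the scatter), changes the group on the carbonyl carbon, not the ring altered here. That step is itself bounded by the limit of > 4 ug/mL in this assay, at which 1 of the 2 values shown sits. Compound 3 `Nc1c(C(=O)c2ccc(F)c(F)c2)sc2nc(-c3cccs3)ccc12` differs from compound 2 by fluoro in place of hydrogen on an aromatic carbon. Within the data shown here, no measured step touches that ring, so no change beyond the scatter is expected. Compound 3 is estimated at 1.8 ug/mL, from 0.9 ug/mL to 3.6 ug/mL, meaning no change at the digits printed from compound 2 to compound 3 (within the scatter).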

Compound 3, half-maximal effective concentration: > 4 ug/mL
Compound 3 was reported as a limit (the forecaster's own chance of this, stated with the estimate: 15%); at least 2.2-fold (0.34 log units) between middle value and limit.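

In this assay, fluoro in place of hydrogen on the 4-fluorophenyl ring, giving 3,4-difluorophenyl, brings an at least 2.2-fold higher number from compound 2 to compound 3 (0.34 log units; beyond the scatter). This ring, untouched by the earlier step, therefore responds to a single added fluoro with a shift beyond the scatter. Compound 3 is reported only as a limit, so the full size of this step stays unknown and the step from compound 1 to compound 3 cannot be read: the limit of > 4 ug/mL in this assay, at which 2 of the 3 values shown sit.

As far as these compounds go, whether the shift belongs to fluoro itself stays open. A chloro or methoxy group on the same carbon would test this.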